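Replacing 2,4-dichlorophenyl with pyridin-4-yl in compound 1

This account rests on a few compounds, and the source may have more. Where it says the series, first, only, none or still open, it means among the compounds named here.

Measured so far in an ADME assay on Vero cells (Chlorocebus sabaeus) for cytotoxicity, read by luminescence, with a stated time of 2 days (a lower number here means that less compound is tolerated, a higher number that more compound is tolerated), as the read-out:
- compound 1 (`CCc1nc2ccccc2n1CCCCOc1ccc(Cl)cc1Cl`): (23 uM)
- compound 2 (`Nc1nc2ccccc2n1CCCCOc1ccccc1`): ("not determined" (no result reported))

Among the measured compounds shown here, compound 1 holds the only number so far, so it cannot yet be ranked against anything, and compound 2 offers no comparison. The next compound, compound 3 (`CCc1nc2ccccc2n1CCCCOc1ccncc1`), has pyridin-4-yl in place of 2,4-dichlorophenyl on an oxygen on a saturated carbon, and the count of what leaves and what enters reads (pyridin-4-yl in place of 2,4-dichlorophenyl on an oxygen on a saturated carbon). For the measured compounds named here, no pair of measured compounds shows what such a swap does in this assay, so any expectation here is loose. Starting from compound 1 at (23 uM), a modest move toward more compound being tolerated seems the likelier direction, though a result close to that number would be no surprise. The estimated change is a 2.2-fold higher number from compound 1 to compound 3 (0.34 log units; beyond the scatter) and remains an expectation only. For compound 3 the estimated half-maximal toxic concentration is (50 uM), expected to lie between (18 uM) and (100 uM).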

Compound 3, half-maximal toxic concentration: > 50 uM
Compound 3 ended at the assay's limit (the forecaster's own chance of this, stated with the estimate: 20%); the middle value lies on the limit itself.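

In this assay compound 3 gives > 50 uM, which is a limit of the assay and not a number. Among the compounds shown here, putting pyridin-4-yl in place of 2,4-dichlorophenyl on the oxygen gives an at least 2.1-fold higher number from compound 1 to compound 3 (0.33 log units; beyond the scatter), the first readable step in this set, and it shows that a change at this place can shift the tolerated concentration by more than repeat measurements would. Only the lower end of that step can be stated, since its true size may be larger and the result sits at the edge of what the assay reports: the limit of > 50 uM in this assay, at which 1 of the 3 values shown sits.

The swap removes both chlorine atoms and brings a nitrogen into the ring in one move, so the compounds shown leave open which of these changes accounts for the step. As far as these compounds go, a 4-chlorophenyl group on the core of compound 1 would help to separate the two, while how far past its limit compound 3 truly lies remains unknown.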